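A swap on the chain carbon of compound 3

The source may report more compounds than this note shows. Statements on the series, on what has been measured and on what is new or still open speak of the compounds shown alone.

Values in a functional assay on DU-145 cells (Homo sapiens) for inhibition, read by trypan blue exclusion, with a stated time of 96 h (on this read-out higher numbers stand for weaker inhibition of growth and lower numbers for stronger inhibition of growth), are these:
- Compound 1 `O=C(/C(=C\c1c(O)cc(O)cc1O)S(=O)(=O)c1ccccc1Br)c1ccc(Br)cc1` gives 50000 nM
- Compound 2 `COc1ccccc1/C=C(\C(=O)c1ccc(Br)cc1)S(=O)(=O)c1ccc(C)cc1` gives 1000 nM
- Compound 3 `Cc1ccc(S(=O)(=O)/C(=C/c2c(O)cc(O)cc2O)C(=O)c2ccc(Br)cc2)cc1` gives > 100000 nM (a limit)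

Compound 3 stands only at a limit, (the limit of > 100000 nM in this assay, at which 1 of the 3 values shown sits).

Compound 4 `CSc1ccc(/C=C(\C(=O)c2ccc(Br)cc2)S(=O)(=O)c2ccc(C)cc2)cc1` carries 4-(methylsulfanyl)phenyl in place of 2,4,6-trihydroxyphenyl on a double-bonded chain carbon bound to a double-bonded chain carbon on a double-bonded chain carbon bound to a double-bonded chain carbon.

The closest guide is an at least 100-fold higher number from compound 2 to compound 3 (2.00 log units; beyond the scatter), a change at that same place. The other step, an at least 2.0-fold higher number from compound 1 to compound 3 (0.30 log units; that floor lies within the scatter), concerns a sulfonyl sulfur and says little here.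

Compound 2 also lacks 2,4,6-trihydroxyphenyl and gives 1000 nM in this assay.

A large step toward a lower number is therefore expected, estimated as an at least 66-fold lower number from compound 3 to compound 4 (1.82 log units; beyond the scatter) in this assay.

For compound 4 the expected value is 1500 nM, with an estimated range of 250 nM to 10000 nM in this assay.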

Compound 4, concentration for 50% growth inhibition: 1000 nM
Beside the measured number, compound 4's estimate is 1.5-fold (0.18 log units) above it, within the range that was stated.
By their numbers in this assay, from the lowest: compounds 2 and 4 (each within the scatter of the next); then compound 1. At a limit, above all of these: compound 3.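

In this assay, 4-(methylsulfanyl)phenyl gives an at least 100-fold lower number from compound 3 to compound 4 (2.00 log units; beyond the scatter), so 2-methoxyphenyl is no longer the only replacement for 2,4,6-trihydroxyphenyl at this place to give a large step. Compound 3 stands only at a limit, so that step is a floor: the limit of > 100000 nM in this assay, at which 1 of the 4 values shown sits. The two replacements read alike, with no change at the digits printed from compound 2 to compound 4 (within the scatter).

From the compounds shown here alone, whether an amine or a carboxylic acid at this place would give a number like those of compound 2 and compound 4 stays open. So does the effect of 4-(methylsulfanyl)phenyl with 2-bromophenyl on the sulfonyl sulfur.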